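Cyclopropyl Replacing Methoxycyclobutyl on an Amide Carbonyl

The source may report more compounds than this note shows. Statements on the series, on what has been measured and on what is new or still open speak of the compounds shown alone.

Of the compounds shown here, two sharing one core have been measured in an ADME assay on the whole organism (Canis lupus familiaris, strain Beagle) for pharmacokinetics; a lower number here means slower removal, a higher number faster removal of the compound. Compound 1 `CCn1c(-c2cnc(C)nc2)nc2c(O[C@H]3CCN(C(=O)C4CC4)C3)ncnc21` gives 4.9 mL/min/kg in this assay. Compound 2 `CCn1c(-c2cnc(C)nc2)nc2c(N[C@H]3CCN(C(=O)[C@H]4C[C@@H](OC)C4)C3)ncnc21`, which carries an amine link instead of an ether link and a different group on the amide carbonyl, gives 7.1 mL/min/kg in this assay. The gap between these two readings is smaller than the usual scatter of repeated measurements, so compound 2 cannot be set apart from compound 1 on this evidence.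

Compound 3 `CCn1c(-c2cnc(C)nc2)nc2c(N[C@H]3CCN(C(=O)C4CC4)C3)ncnc21` has not yet been measured. It differs from compound 2 in one place: cyclopropyl in place of 3-methoxycyclobutyl on a carbonyl carbon. Going by the values given here, no measured pair isolates exactly this change, so the expectation rests on the two values shown and on compound 1, which carries the same cyclopropyl group on its carbonyl carbon and gives 4.9 mL/min/kg. The step of a 1.3-fold lower number from compound 2 to compound 3 (0.11 log units; within the scatter) is expected to be small, within the scatter, leaning if anything toward slower removal. Compound 3 is therefore estimated at 5.5 mL/min/kg, with a range from 3 mL/min/kg to 10 mL/min/kg.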

Compound 3, clearance: 4.3 mL/min/kg
Compound 3: the middle estimate sits 1.3-fold (0.11 log units) above what was measured, within the range that was stated.
By their numbers in this assay, from the lowest: compounds 3, 1 and 2 (each within the scatter of the next).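

In this assay, going by these compounds alone, this change is now seen on its own for the first time, with a 1.7-fold lower number from compound 2 to compound 3 (0.22 log units; within the scatter), so the two compounds cannot be told apart. On this carbonyl carbon, then, 3-methoxycyclobutyl and the smaller cyclopropyl give clearance readings that lie within the usual scatter, even though the change also removes the methoxy oxygen and both defined stereocentres of that group. Compound 3 also forms a one-place pair with compound 1, which has an ether link instead of an amine link: compound 1 gives 4.9 mL/min/kg and compound 3 gives 4.3 mL/min/kg, and these two readings also lie within the scatter of each other.

Nothing shown here gives a reason why these readings stay so close. Going by these compounds, it also remains open whether a plain cyclobutyl ring without the methoxy, a longer chain such as n-butyl, or an amine attached to this carbonyl carbon would keep the reading in the same range or move it beyond the scatter.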